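The compounds below may be only part of what the source reports. "The series", "measured", "known", "first", "only" and "open" are said of these compounds alone.

For the measured compounds named here, compound 1 `O=C(CCc1ccc(C(F)(F)F)cc1)Nc1ccc2nc(N3CCC3)ccc2c1` gives 56 nM in a functional assay on HEK293 cells for activation of melanin-concentrating hormone receptor 1 (Rattus norvegicus), read by inositol phosphate accumulation (a higher number here means that more compound is needed for the effect, a lower number that less compound is needed), and stands lowest of the two numbers so far; the only other measured member, compound 2 `CN(c1ccc2cc(NC(=O)CCc3ccc(C(F)(F)F)cc3)ccc2n1)C1CCCCC1`, gives 1200 nM in this assay. Going by the values given here, the single measured step, a 21-fold higher number from compound 1 to compound 2 (1.33 log units; beyond the scatter), shows a larger group at this carbon of the shared core raising the number. Compound 3 `CC(=O)NC1CCN(c2ccc3cc(NC(=O)CCc4ccc(C(F)(F)F)cc4)ccc3n2)C1` carries 3-acetamidopyrrolidin-1-yl in place of azetidin-1-yl on an aromatic carbon. Among the compounds with values here, only that step bears on the present change, and the entering group is again larger than azetidin-1-yl, so a rise is expected, though a smaller one than for compound 2. For compound 3 the expected number is 200 nM, within 70 nM to 700 nM. The expected step is a 3.6-fold higher number from compound 1 to compound 3 (0.55 log units; beyond the scatter).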

Compound 3, half-maximal effective concentration: 440 nM
Compound 3: middle estimate off by 2.2-fold (0.34 log units), on the low side; low and high end bracket the measured number.
By their numbers in this assay, from the lowest: compound 1; then compound 3; then compound 2.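

In this assay, a second replacement of azetidin-1-yl on this aromatic carbon also raises the number, with a 7.9-fold higher number from compound 1 to compound 3 (0.90 log units; beyond the scatter) as the step, so azetidin-1-yl still gives the lowest number of the three. 3-Acetamidopyrrolidin-1-yl nevertheless stands lower than cyclohexyl(methyl)amino, with a 2.7-fold lower number from compound 2 to compound 3 (0.44 log units; beyond the scatter) as the step, so replacements of azetidin-1-yl here differ in how far they raise the number. Nothing measured gives a reason for either step.

On these data alone, whether the ring or its acetamido group sets this number stays open. Plain pyrrolidin-1-yl and 3-aminopyrrolidin-1-yl would help to separate the two.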